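Swapping the thiophene for a pyrimidine in a nicotinic ligand

The source may report more compounds than this note shows. Statements on the series, on what has been measured and on what is new or still open speak of the compounds shown alone.

Measured compounds:
compound 1 `Cc1ccccc1-c1cncc(OC[C@@H]2CCCN2C)c1`: 1.1 nM
compound 2 `CN1CCC[C@H]1COc1cncc(-c2cccs2)c1`: 0.31 nM

Within the data shown here, in an assay on membranes from brain for binding affinity to Neuronal acetylcholine receptor; alpha4/beta2 (Rattus norvegicus) (a higher number here means a weaker inhibitor, a lower number a stronger inhibitor), compound 2 gives the lowest of the two numbers; its only neighbour is compound 1, with a step of a 3.5-fold lower number from compound 1 to compound 2 (0.55 log units; beyond the scatter). Compound 3 `CN1CCC[C@H]1COc1cncc(-c2cncnc2)c1` differs from compound 2 in one place: pyrimidin-5-yl in place of thiophen-2-yl on an aromatic carbon. Among the measured compounds shown here, no measured step exchanges a thiophene for a pyrimidine, so only the modest size of the step from compound 1 to compound 2 guides the expectation. A step of similar size, toward a higher number, is expected for compound 3, a 3.2-fold higher number from compound 2 to compound 3 (0.51 log units; beyond the scatter). Compound 3 is estimated at 1 nM in this assay, between 0.3 nM and 4 nM.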

Compound 3, inhibition constant: 0.37 nM
Estimate against measurement, compound 3: 2.7-fold (0.43 log units) above; the range from low to high includes it.
By their numbers in this assay, from the lowest: compounds 2 and 3 (each within the scatter of the next); then compound 1.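

In this assay, pyrimidin-5-yl and thiophen-2-yl on this aromatic carbon cannot be told apart, with a 1.2-fold higher number from compound 2 to compound 3 (0.08 log units; within the scatter). A six-membered aromatic ring with 2 hetero atoms therefore reads here like a five-membered one with 1 hetero atom. Compared with 2-methylphenyl, pyrimidin-5-yl shows a 3.0-fold lower number from compound 1 to compound 3 (0.47 log units; beyond the scatter), much as thiophen-2-yl did. No available evidence bears on this result. Still open, from the compounds shown here alone, is whether the same tolerance extends to a group that is not an aromatic ring, such as an amine or a carboxylic acid, at this place.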